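Methoxy-to-hydroxy loss and a methoxyphenyl swap

The source may report more compounds than this note shows. Statements on the series, on what has been measured and on what is new or still open speak of the compounds shown alone.

Compound 1 `COc1cccc(C(=O)Nc2cccc(-c3cc(=O)c4c(OC)c(OC)c(OC)cc4o3)c2)c1` and compound 2 `COc1ccccc1C(=O)Nc1cccc(-c2cc(=O)c3c(OC)c(OC)c(OC)cc3o2)c1` share a core and differ as 2-methoxyphenyl in place of 3-methoxyphenyl on a carbonyl carbon; in a functional assay on HepG2 cells (Homo sapiens) for inhibition, read by MTT assay (a lower number here means a stronger inhibitor of growth, a higher number a weaker inhibitor of growth), compound 1 gives 7060 nM and compound 2 gives 7530 nM, a step of a 1.1-fold higher number from compound 1 to compound 2 (0.03 log units; within the scatter). Compound 3 `COc1cccc(C(=O)Nc2cccc(-c3cc(=O)c4c(O)c(OC)c(OC)cc4o3)c2)c1` differs from compound 1 as hydrogen in place of methyl on an oxygen on an aromatic ring. In this assay compound 3 reaches only the limit > 100000 nM, so its value is a limit and not a number; the step is an at least 14-fold higher number from compound 1 to compound 3 (1.15 log units; beyond the scatter), which rests on (the limit of > 100000 nM in this assay, at which 1 of the 3 values shown sits). Compound 4 `COc1ccccc1C(=O)Nc1cccc(-c2cc(=O)c3c(O)c(OC)c(OC)cc3o2)c1` differs from compound 3 as 2-methoxyphenyl in place of 3-methoxyphenyl on a carbonyl carbon, the same change as from compound 1 to compound 2, at the same place. Because the measured step of a 1.1-fold higher number from compound 1 to compound 2 (0.03 log units; within the scatter) lay within the scatter, compound 4 is expected to stay close to compound 3, with an expected step that the limit leaves unreadable from compound 3 to compound 4. Compound 4 is estimated at 150000 nM in this assay, most likely again reported only as a limit.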

Compound 4, concentration for 50% growth inhibition: > 100000 nM
Compound 4 gave a limit, no number; the forecaster's own chance of this, stated with the estimate: 75%; the middle value is on the limit's open side.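

In this assay, hydrogen in place of methyl on an oxygen on an aromatic ring gives an at least 13-fold higher number from compound 2 to compound 4 (1.12 log units; beyond the scatter), so the large loss seen with the 3-methoxyphenyl group recurs with the 2-methoxyphenyl group, in the only two pairs shown: the same change on two cores in this assay, an at least 14-fold higher number (1.15 log units; beyond the scatter) from compound 1 to compound 3 and an at least 13-fold higher number (1.12 log units; beyond the scatter) from compound 2 to compound 4; the limit leaves it open whether they differ

Neither the size of the loss on each core nor any gap between the two steps can be read, and the step from the 3-methoxyphenyl to the 2-methoxyphenyl group among the hydroxy compounds cannot be read either: the limit of > 100000 nM in this assay, at which 2 of the 4 values shown sit.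

Still open, from the compounds shown here alone, is what a longer chain, such as ethyl, would do in place of that methyl on the oxygen. Also open, going by these compounds, is how an amine in place of methoxy on the phenyl ring would read in this assay.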